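The source may hold more compounds than are shown below. What is called first, only, known or untested is meant among the compounds shown, and "the series" means these compounds.

Among the measured compounds shown here, compound 1 `COc1cc(N2C(N)=C(C#N)C(c3cccs3)C3=C2CC(C)(C)CC3=O)cc(OC)c1OC` is one of two compounds measured in a functional assay on Ehrlich cells (Mus musculus) for cytotoxicity, tested at 25 ug/mL (on this read-out higher numbers stand for a stronger effect at the one concentration tested and lower numbers for a weaker effect), and in that assay compound 1 gives 10%, the lower of the two numbers. Its nearest neighbour is compound 2 `COc1cc(N2C(N)=C(C#N)C(c3ccc(C)cc3)C3=C2CC(C)(C)CC3=O)cc(OC)c1OC`, which in this assay gives 50%. For the measured compounds named here, the single measured step, a number 40 percentage points higher from compound 1 to compound 2 (beyond the scatter), puts 4-methylphenyl in place of thiophen-2-yl on a saturated ring carbon of the shared core.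

The compound still to be measured is compound 3 `COc1cc(N2C(N)=C(C#N)C(c3ccccc3O)C3=C2CC(C)(C)CC3=O)cc(OC)c1OC`. It differs from compound 1 by 2-hydroxyphenyl in place of thiophen-2-yl on a saturated ring carbon. Going by the values given here, the step from compound 1 to compound 2 bears on this change only in part: both replace the five-membered aromatic ring with one hetero atom by a six-membered aromatic ring of carbon only at the same saturated ring carbon, but 2-hydroxyphenyl carries one hydrogen-bond donor that 4-methylphenyl does not, so no measured pair matches it exactly. A rise beyond the scatter seems the likelier outcome, though smaller and less certain than the measured one.

Compound 3 is therefore estimated to give 35% in this assay, within 10% to 60%. This expected result amounts to a number 25 percentage points higher from compound 1 to compound 3 (beyond the scatter).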

Compound 3, a percentage reported as activity, at one concentration (the size of the read-out at that concentration, not a potency): 0%
Beside the measured number, compound 3's estimate is 35 percentage points above it; the measured number lies below the stated range.
By their numbers in this assay, from the lowest: compounds 3 and 1 (each within the scatter of the next); then compound 2.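

In this assay, the change to 2-hydroxyphenyl gives a number 10 percentage points lower from compound 1 to compound 3 (within the scatter), so a six-membered aromatic ring of carbon only at this saturated ring carbon does not by itself bring the gain that compound 2 showed. The change from 4-methylphenyl to 2-hydroxyphenyl at the same carbon gives a number 50 percentage points lower from compound 2 to compound 3 (beyond the scatter), which shows that the effect here depends on what the six-membered ring carries, not just on the ring being there. No measurement at hand explains this difference.

These two groups differ in both the substituent and where it sits on the ring, so the compounds shown cannot separate those two changes. Plain phenyl, 2-methylphenyl and 4-hydroxyphenyl at this carbon would help to tell them apart, while a ring bearing an amine or a carboxylic acid would test whether anything other than methyl can give a similar result.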